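Replacing the 3-fluoro-4-methoxyphenyl group of compound 3

A few compounds are considered here, and "the series" means these few. Any claim that something is new, unique, unknown or untested is made for them only; others in the source may bear on it.

In a functional assay on KBVIN cells (Homo sapiens) for antiproliferative activity, read by sulforhodamine B assay, with a stated time of 3 days (on this read-out higher numbers stand for an effect only at larger amounts of compound and lower numbers for an effect already at smaller amounts), three compounds on a shared core have been measured so far. Compound 1 (`CCC1=C(O)c2c(oc(-c3cccc(F)c3)cc2=O)C(CC)(CC)C1=O`) gives 3.09 uM, compound 2 (`CCC1=C(O)c2c(oc(-c3ccc(C)cc3C)cc2=O)C(CC)(CC)C1=O`) gives 8.52 uM and compound 3 (`CCC1=C(O)c2c(oc(-c3ccc(OC)c(F)c3)cc2=O)C(CC)(CC)C1=O`) gives 0.1 uM. Compound 3 therefore holds the lowest number of the three.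

Compound 4 (`CCC1=C(O)c2c(oc(-c3cc(C)ccc3C)cc2=O)C(CC)(CC)C1=O`) carries 2,5-dimethylphenyl in place of 3-fluoro-4-methoxyphenyl, on an aromatic carbon next to the ring oxygen: 2,5-dimethylphenyl in place of 3-fluoro-4-methoxyphenyl on an aromatic carbon.

Among the compounds with values here, three measured steps bear on this change. The nearest comparison is compound 2, whose 2,4-dimethylphenyl group is the closest to the entering group. Its step, an 85-fold lower number from compound 2 to compound 3 (1.93 log units; beyond the scatter), is large and runs opposite to the change considered here. The step of a 31-fold lower number from compound 1 to compound 3 (1.49 log units; beyond the scatter), with methoxy in place of hydrogen, is also large, and compound 4 has no methoxy. The step of a 2.8-fold higher number from compound 1 to compound 2 (0.44 log units; beyond the scatter) is modest. Within the data shown here, no measured pair compares 2,4-dimethylphenyl with 2,5-dimethylphenyl directly, so the range stays wide.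

In this assay, a large step toward a higher number is expected, estimated as a 60-fold higher number from compound 3 to compound 4 (1.78 log units; beyond the scatter). For compound 4 the estimated value is 6 uM, with an expected range from 2 uM to 18 uM.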

Compound 4, concentration for half-maximal effect: 3.41 uM
The estimate for compound 4 lay 1.8-fold (0.25 log units) above the measured number; measured number inside the range.
By their numbers in this assay, from the lowest: compound 3; then compounds 1 and 4 (each within the scatter of the next); then compound 2.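

In this assay the change to 2,5-dimethylphenyl gives a 34-fold higher number from compound 3 to compound 4 (1.53 log units; beyond the scatter) and so places a second dimethylphenyl group far from compound 3; the high number of compound 2 is therefore not confined to its 2,4-dimethylphenyl pattern. Within the data shown here, the first direct comparison of the two methyl patterns at this position gives a 2.5-fold lower number from compound 2 to compound 4 (0.40 log units; beyond the scatter) and shows that the arrangement of the methyl groups on this ring still changes the read-out, though much less than the loss of the 3-fluoro-4-methoxyphenyl group does. The comparison with 3-fluorophenyl gives a 1.1-fold higher number from compound 1 to compound 4 (0.04 log units; within the scatter) and leaves compound 1 and compound 4 indistinguishable, so among the four compounds only the 3-fluoro-4-methoxyphenyl group of compound 3 stands apart.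

Still open, from the compounds shown here alone, is how far the low number of compound 3 depends on its methoxy group, and whether an ethoxy group or an amine at that place on the ring would keep it. No measurement at hand accounts for any of these differences.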